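The compounds below may be only part of what the source reports. "The series", "measured", "known", "first", "only" and "open" are said of these compounds alone.

Compound 1 `CCc1nc2c(C(=O)NCC3CCN(CC(O)CN4CCN(S(C)(=O)=O)CC4)CC3)cccc2[nH]1` is the reference point of this pair of benzimidazole carboxamide analogues. Going by the values given here, in an assay on isolated protein for binding affinity to 5-hydroxytryptamine receptor 4 (Homo sapiens) (a lower number here means a stronger inhibitor, a higher number a weaker inhibitor), compound 1 gives 0.501 nM, the lower of the two numbers measured so far. The nearest measured neighbour is compound 2 `CC(=O)N(C)CC(O)CN1CCC(CNC(=O)c2cccc3[nH]c(C(C)C)nc23)CC1`, which carries isopropyl on the core and a different side chain; in this assay compound 2 gives 3.98 nM, a gap beyond the usual scatter, though the two compounds differ in more than one place, so no single step can be read from them.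

Compound 3 `CC(C)(C)c1nc2c(C(=O)NCC3CCN(CC(O)CN4CCN(S(C)(=O)=O)CC4)CC3)cccc2[nH]1` keeps the side chain of compound 1 unchanged; the only difference is tert-butyl in place of ethyl on an aromatic carbon.

Among the compounds with values here, no measured step of this kind exists. The expectation for compound 3 is a step from compound 1 of a 1.6-fold higher number from compound 1 to compound 3 (0.20 log units; within the scatter), that is, no change beyond the scatter or a mild loss. Compound 3 is therefore estimated at 0.8 nM, with a range from 0.25 nM to 3 nM in this assay.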

Compound 3, inhibition constant: 12.6 nM
Compound 3: the middle estimate sits 16-fold (1.20 log units) below what was measured; the measured number lies above the stated range.
By their numbers in this assay, from the lowest: compound 1; then compound 2; then compound 3.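

In this assay, the position on an aromatic carbon of the five-membered aromatic ring, between two ring nitrogen atoms, does not accept every alkyl group alike: tert-butyl in place of ethyl gives a 25-fold higher number from compound 1 to compound 3 (1.40 log units; beyond the scatter) with the side chain unchanged. This is the only single-place step shown, and it makes this position, rather than the side chain alone, a demonstrated source of a large change in this series. No measurement at hand bears on the origin of this step.

Whether the number rises gradually between ethyl and tert-butyl cannot be read, since the isopropyl of compound 2 comes with a different side chain. Also open, from the compounds shown here alone, is how methyl, cyclopropyl or a primary amine at this position would compare on the side chain of compound 1.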